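The source may report more compounds than this note shows. Statements on the series, on what has been measured and on what is new or still open speak of the compounds shown alone.

Compound 2 `CC(=O)Nc1cccc(-n2c(Nc3ccc(F)cc3)nc3cnc(Nc4ccc(N5CCN(C)CC5)cc4)nc32)c1` gives 10 nM in a functional assay on HCC827 cells (Homo sapiens) for antiproliferative activity, read by MTT assay, with a stated time of 72 h; on this read-out lower numbers stand for stronger inhibition and higher numbers for weaker inhibition. Compound 1 `CN1CCN(c2ccc(Nc3ncc4nc(Nc5ccc(F)cc5)n([C@H]5CCNC5)c4n3)cc2)CC1` gives 1220 nM in this assay.

For the measured compounds named here, on these two numbers compound 2 stands lowest, and the only measured step, a 120-fold lower number from compound 1 to compound 2 (2.09 log units; beyond the scatter), bears directly on the change at hand. Compound 3 `CNC(=O)CN1CC[C@H](n2c(Nc3ccc(F)cc3)nc3cnc(Nc4ccc(N5CCN(C)CC5)cc4)nc32)C1` carries the change (1-((methylcarbamoyl)methyl)pyrrolidin-3-yl in place of 3-acetamidophenyl on an aromatic nitrogen), which returns a pyrrolidin-3-yl ring to the aromatic nitrogen, though now bearing a (methylcarbamoyl)methyl chain that compound 1 lacks. Going by these compounds, because compound 1 gives 1220 nM, a rise is expected, but the added chain is untested, so a smaller step than that is estimated: a 15-fold higher number from compound 2 to compound 3 (1.18 log units; beyond the scatter). Compound 3 is therefore expected to give 150 nM, between 30 nM and 800 nM.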

Compound 3, half-maximal inhibitory concentration: 1520 nM
Estimate against measurement, compound 3: 10-fold (1.01 log units) below; the measured number lies above the stated range.
By their numbers in this assay, from the lowest: compound 2; then compounds 1 and 3 (each within the scatter of the next).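

On this aromatic nitrogen, 1-((methylcarbamoyl)methyl)pyrrolidin-3-yl in place of 3-acetamidophenyl gives a 150-fold higher number from compound 2 to compound 3 (2.18 log units; beyond the scatter) in this assay, so the low number stays with the aryl group among these compounds. With (methylcarbamoyl)methyl in place of hydrogen on the ring amine nitrogen, a 1.2-fold higher number from compound 1 to compound 3 (0.10 log units; within the scatter) leaves the two pyrrolidin-3-yl compounds indistinguishable. No evidence explains these numbers. Going by these compounds, it remains open whether a carboxylic acid or a longer chain on that ring nitrogen would separate from these values, and whether the acetamido group matters to the phenyl compound, as against a plain phenyl or an amine.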